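This account rests on a few compounds, and the source may have more. Where it says the series, first, only, none or still open, it means among the compounds named here.

Compound 3 `CCCCCCCCCCCCn1nnc(C(C(=O)Nc2c(OC)cc(OC)cc2OC)c2ccccn2)n1` gives 590 nM in an assay on liver for inhibition of sterol O-acyltransferase 1 (Rattus norvegicus), using microsomes (a higher number here means a weaker inhibitor, a lower number a stronger inhibitor), the lowest of the three numbers, though compound 1 `CCCCCCCCCCCCn1nnc(C(C(=O)Nc2c(OC)cc(OC)cc2OC)c2ccc(N(C)C)cc2)n1` gives 659 nM and sits within the scatter of compound 3; compound 2 `CCCCCCCCCCCCn1nnc(C(F)C(=O)Nc2c(OC)cc(OC)cc2OC)n1` gives 1760 nM. Compound 4 `CCCCCCCCCCCCn1nnc(CC(=O)Nc2c(OC)cc(OC)cc2OC)n1` carries hydrogen in place of pyridin-2-yl on a saturated chain carbon bound to an aromatic carbon and a carbonyl carbon. For the measured compounds named here, two measured steps bear on taking the six-membered ring off that carbon: a 2.7-fold higher number from compound 1 to compound 2 (0.43 log units; beyond the scatter) and a 3.0-fold lower number from compound 2 to compound 3 (0.47 log units; beyond the scatter). Both show a modest cost when fluoro stands there instead of 4-(dimethylamino)phenyl or pyridin-2-yl, and hydrogen, like fluoro, leaves no ring on that carbon. A modest weakening is therefore expected, a 2.7-fold higher number from compound 3 to compound 4 (0.43 log units; beyond the scatter). The estimate for compound 4 is 1600 nM, with a range from 550 nM to 4800 nM.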

Compound 4, half-maximal inhibitory concentration: 24 nM
Beside the measured number, compound 4's estimate is 67-fold (1.82 log units) above it, outside the stated range (below it).
By their numbers in this assay, from the lowest: compound 4; then compounds 3 and 1 (each within the scatter of the next); then compound 2.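

In this assay, hydrogen on the saturated chain carbon bound to an aromatic carbon and a carbonyl carbon stands far apart from all three other groups: a 25-fold lower number from compound 3 to compound 4 (1.39 log units; beyond the scatter) on losing pyridin-2-yl, a 27-fold lower number from compound 1 to compound 4 (1.44 log units; beyond the scatter) on losing 4-(dimethylamino)phenyl, and a 73-fold lower number from compound 2 to compound 4 (1.87 log units; beyond the scatter) on losing fluoro. Having no ring on that carbon does not by itself give the low number, as fluoro also leaves none there. The data offer no measured explanation for this gain.
Still open, as far as these compounds go, is whether the low number belongs to hydrogen alone or also survives a small group such as methyl or hydroxyl on that carbon.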